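From dimethylamino to amino on compound 1

The source may report more compounds than this note shows. Statements on the series, on what has been measured and on what is new or still open speak of the compounds shown alone.

Measured so far in a physicochemical assay for lipophilicity, using the shake flask method, at pH 7.4; a higher number here means a more lipophilic compound, a lower number a more polar compound
- compound 1 `COC(=O)N1CCN([C@H]2CC[C@H](Nc3ncnn4ccc([C@H](C)CC(=O)N(C)C)c34)CC2)CC1` at 2.3
- compound 2 `CC(C)c1ccn2ncnc(N[C@H]3CC[C@H](N(C)C)CC3)c12` at 1.3
- compound 3 `CC(C)n1ccc2ncnc(N[C@H]3CC[C@H](N(C)C)CC3)c21` at 0.1

Compound 1 stands highest of the three, beyond the scatter of both others. Compound 4 `COC(=O)N1CCN([C@H]2CC[C@H](Nc3ncnn4ccc([C@H](C)CC(N)=O)c34)CC2)CC1` differs from compound 1 by one change (amino in place of dimethylamino on a carbonyl carbon), with amino in place of dimethylamino on a carbonyl carbon. Within the data shown here, no measured pair in this set shows this change, so the expectation rests on the structural change alone. The expected step of a number 0.50 log units lower from compound 1 to compound 4 (beyond the scatter) is downward in this assay and somewhat beyond the scatter. Compound 4 is estimated at 1.8 within an expected range of 1.4 to 2.2 in this measurement.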

Compound 4, distribution coefficient: 1.9
Compound 4: the middle estimate sits 0.10 log units below what was measured; the measured number falls inside the stated range.
By their numbers in this assay, from the lowest: compound 3; then compound 2; then compound 4; then compound 1.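

In this assay the series now has its first step at a single place: amino in place of dimethylamino on a carbonyl carbon gives a number 0.40 log units lower from compound 1 to compound 4 (beyond the scatter) and stays modest, though beyond the scatter. Since the remainder of the structure is unchanged, this number belongs to that one change at this position. No available evidence accounts for the size of the step.

Open, as far as these compounds go, is how a methylamino group or a carboxylic acid on the same carbonyl carbon would read. Also open, from the compounds shown here alone, is whether this step holds on compounds with a different substituent on the shared core.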